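A few compounds are considered here, and "the series" means these few. Any claim that something is new, unique, unknown or untested is made for them only; others in the source may bear on it.

In an ADME assay on MT4 cells (Homo sapiens) for cytotoxicity, read by MTT assay, with a stated time of 4 days (a higher number here means that more compound is tolerated, a lower number that less compound is tolerated), two compounds have been measured so far:

Compound 1 `Cc1ccc(/C=N/NC(=O)COc2cccc3ccccc23)cc1` gives 83.9 ug/mL.
Compound 2 `O=C(COc1cccc2ccccc12)N/N=C/c1cccc(O)c1` gives 32.6 ug/mL.

Among the measured compounds shown here, compound 2 stands at the lower of these two numbers; its only neighbour is compound 1, and the single measured step is a 2.6-fold lower number from compound 1 to compound 2 (0.41 log units; beyond the scatter). Compound 3 `O=C(COc1cccc2ccccc12)N/N=C/c1ccccc1Cl` differs from compound 2 in one place: 2-chlorophenyl in place of 3-hydroxyphenyl on a carbon with a double bond to nitrogen.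

For the measured compounds named here, no measured step involves a 2-chlorophenyl group, so nothing bears directly on this change. Going by the values given here, the one step that exists, from compound 1 to compound 2, shows that exchanging the aryl group on the carbon with a double bond to nitrogen can move the number by a modest, real amount, and the direction in that case was downward when the 3-hydroxyphenyl entered. With the 3-hydroxyphenyl now leaving, a modest rise is expected for compound 3, a 1.7-fold higher number from compound 2 to compound 3 (0.23 log units; within the scatter), though it may also fall within the scatter. Compound 3 is therefore estimated at 55 ug/mL, with a range from 25 ug/mL to 120 ug/mL.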

Compound 3, half-maximal cytotoxic concentration: 56.2 ug/mL
Compound 3: the middle estimate sits 1.0-fold (0.01 log units) below what was measured; the range from low to high includes it.
By their numbers in this assay, from the lowest: compounds 2, 3 and 1 (each within the scatter of the next, the first and the last beyond it).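

In this assay the carbon with a double bond to nitrogen now carries a third aryl group, and the 2-chlorophenyl group leaves compound 3 within the scatter of both earlier compounds (a 1.7-fold higher number from compound 2 to compound 3 (0.24 log units; within the scatter); a 1.5-fold lower number from compound 1 to compound 3 (0.17 log units; within the scatter)). Among the compounds shown here, the one step beyond the scatter, between compound 1 and compound 2, therefore now has a compound lying between its ends, even though 2-chlorophenyl counts no hydrogen-bond donor or acceptor and 3-hydroxyphenyl counts one of each. Nothing available explains how these three aryl groups read in this assay.

From the compounds shown here alone, all three compounds carry a six-membered aromatic ring of carbon at this place, so the effect of an amine or a carboxylic acid on that ring remains open. Also open, going by these compounds, is what a longer chain in place of the ring would do.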